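A few compounds are considered here, and "the series" means these few. Any claim that something is new, unique, unknown or untested is made for them only; others in the source may bear on it.

Compound 1 `CC(C)(C)c1ccc(NC(=O)NCCCCl)cc1`, compound 2 `CC(C)(C)c1ccc(CNC(=O)NCCCCl)cc1` and compound 3 `CCCCCc1cccc(NC(=O)NCCCCl)c1` have been measured in a functional assay on M21 cells (Homo sapiens) for antiproliferative activity, with a stated time of 48 h; a higher number here means a weaker inhibitor, a lower number a stronger inhibitor. In this assay compound 1 gives 35000 nM, compound 2 gives 11000 nM and compound 3 gives 24000 nM. Among these three numbers compound 3 holds the second highest; compound 1 is its nearest neighbour and the two lie within the scatter of each other, so no order between them is claimed. Compound 2 is furthest away and gives a lower number than compound 3, a gap that is beyond the scatter. Among the compounds with values here, no two of the measured compounds differ in only one place, so no single-change step is on record within the measured set.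

Compound 4 `CCCCC(O)c1cccc(NC(=O)NCCCCl)c1` has not yet been measured in this assay. It differs from compound 3 by one change: hydroxy in place of hydrogen on a saturated chain carbon bound to an aromatic carbon and a saturated chain carbon, which can also be read as pentyl to 1-hydroxypentyl. Within the data shown here, nothing among the measured compounds speaks to this change, since none of them carries a hydroxy on the chain. The expected step in this assay is therefore set close to no change, with a slight lean toward a higher number, as a 1.3-fold higher number from compound 3 to compound 4 (0.10 log units; within the scatter); the expectation rests on the absence of any comparable step rather than on a shown one. For compound 4 the estimate in this assay is 30000 nM, with a range from 10000 nM to 90000 nM.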

Compound 4, half-maximal inhibitory concentration: 35000 nM
Estimate against measurement, compound 4: 1.2-fold (0.07 log units) below; low and high end bracket the measured number.
By their numbers in this assay, from the lowest: compound 2; then compounds 3, 1 and 4 (each within the scatter of the next).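

In this assay, hydroxy in place of hydrogen on a saturated chain carbon bound to an aromatic carbon and a saturated chain carbon gives a 1.5-fold higher number from compound 3 to compound 4 (0.16 log units; within the scatter). Within the data shown here, this pentyl to 1-hydroxypentyl step is the first single-change comparison, and it shows that this chain carbon accepts the hydroxy, with its hydrogen-bond donor and acceptor, without separating compound 4 from compound 3 beyond the scatter. Nothing on record offers an explanation for this result.

The compounds shown leave open whether an amine, a methoxy or a carboxylic acid on this same chain carbon would also stay within the scatter of compound 3. Also open, from the compounds shown here alone, is whether the hydroxy would give a comparable step on a longer chain, since this single step comes from the pentyl compound alone and says nothing about other chain lengths.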